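The source may report more compounds than this note shows. Statements on the series, on what has been measured and on what is new or still open speak of the compounds shown alone.

In a functional assay on PC-3 cells (Homo sapiens) for antiproliferative activity, read by MTT assay, with a stated time of 72 h (on this read-out higher numbers stand for weaker inhibition and lower numbers for stronger inhibition), compound 1 `CCN(CC)CCCNC(=O)c1ccc(C(CC)(CC)c2ccc(C#CC(O)(CC)CC)c(C)c2)n1CC` gives 8500 nM. Compound 2 `CCCCC(=O)c1ccc(C(CC)(CC)c2ccc(C#CC(O)(CC)CC)c(C)c2)n1CC` gives > 50000 nM, which is a limit and not a number; it stands at the limit of > 50000 nM in this assay, at which 1 of the 2 values shown sits. Within the data shown here, only one measured step bears on what follows, at the same carbonyl carbon: an at least 5.8-fold higher number from compound 1 to compound 2 (0.76 log units; beyond the scatter). Compound 3 `CCn1c(C(=O)NCC(=O)O)ccc1C(CC)(CC)c1ccc(C#CC(O)(CC)CC)c(C)c1` changes that place again, with (carboxymethyl)amino in place of butyl on a carbonyl carbon. The lower number of compound 1 at 8500 nM came with a (3-(diethylamino)propyl)amino group, which compound 3 does not carry, so a return to that level is not expected. In this assay, the expected change is small, with no clear direction and nothing beyond the scatter: an at least 1.1-fold lower number from compound 2 to compound 3 (0.04 log units; that floor lies within the scatter). Compound 3 is estimated at 45000 nM, with an expected range from 15000 nM to 100000 nM.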

Compound 3, half-maximal inhibitory concentration: 2250 nM
Estimate against measurement, compound 3: 20-fold (1.30 log units) above; measured number below the stated range.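

In this assay, the diethylamino end of the chain on this carbonyl carbon proves not to be needed for a low number. Replacing it with carboxy gives a 3.8-fold lower number from compound 1 to compound 3 (0.58 log units; beyond the scatter). The earlier pair could not show this, as it only compared that chain with butyl, whereas (carboxymethyl)amino in place of butyl now gives an at least 22-fold lower number from compound 2 to compound 3 (1.34 log units; beyond the scatter). That step is only a floor, and the value of compound 2 is a limit and not a number: the limit of > 50000 nM in this assay, at which 1 of the 3 values shown sits.

The compounds shown leave open whether the gain over butyl comes from the amide nitrogen with its hydrogen or from the carboxy end of the chain. A plain methylamino group, a methyl ester in place of the carboxy group, or a longer chain ending in carboxy would help to separate these two parts.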